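This account rests on a few compounds, and the source may have more. Where it says the series, first, only, none or still open, it means among the compounds named here.

Measured so far in a functional assay on PC-3 cells (Homo sapiens) for antiproliferative activity, read by MTT assay, with a stated time of 72 h; a higher number here means a weaker inhibitor, a lower number a stronger inhibitor:
Compound 1, `CCCSc1nc(Cl)c2c(n1)N(Cc1ccccc1)C(C(=O)O)N2`: 49200 nM.
Compound 2, `CCCSc1nc(Cl)c2c(n1)N(CC1CCCCC1)C(C(=O)N1CCN(C)CC1)N2`: 12800 nM.
Compound 3, `CCCSc1nc(Cl)c2c(n1)N(Cc1ccccc1)C(C(=O)NCCC1=CCc3ccccc31)N2`: a limit of the assay, > 64000 nM.

Compound 1 stands highest of the two numbers in this assay; the nearest is compound 2, whose number is lower by a gap beyond the scatter. The value of compound 3 is a limit only (the limit of > 64000 nM in this assay, at which 1 of the 3 values shown sits).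

Compound 4, `CCCSc1nc(Cl)c2c(n1)N(Cc1ccccc1)C(C(=O)Nc1ccccc1)N2`, differs from compound 1 by anilino in place of hydroxy on a carbonyl carbon. For the measured compounds named here, no measured pair isolates this change; compound 2 carries a different amide and a different group on the ring nitrogen, and compound 3 a different amide again. The step from compound 1 to compound 4 is expected to be small, a 1.1-fold higher number from compound 1 to compound 4 (0.05 log units; within the scatter), with some chance that only a limit is reported. Compound 4 is expected at 55000 nM, between 18000 nM and 170000 nM.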

Compound 4, half-maximal inhibitory concentration: > 64000 nM
Compound 4: only a limit was reported (the forecaster's own chance of this, stated with the estimate: 40%); middle value at least 1.1-fold (0.06 log units) from the limit.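

Compound 4 gives only a limit of the assay in this assay, > 64000 nM. Anilino in place of hydroxy on a carbonyl carbon gives an at least 1.3-fold higher number from compound 1 to compound 4 (0.11 log units; that floor lies within the scatter), so this change brings no lower number here, and the true size of the rise stays unknown. Compound 3 and compound 4 both sit at the limit, so the step between them cannot be read: the limit of > 64000 nM in this assay, at which 2 of the 4 values shown sit.

Open, as far as these compounds go, is whether an anilino group carrying an amine, or a benzylamino group in its place, comes in under the limit. For the compounds shown here, compound 2 differs from the others in more than one place, so no step to it isolates the amide.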